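A few compounds are considered here, and "the series" means these few. Any claim that something is new, unique, unknown or untested is made for them only; others in the source may bear on it.

Values so far in an ADME assay on cells (Hepatocyte, Mus musculus) for metabolic stability, with a stated time of 30 min; on this read-out higher numbers stand for a more stable compound and lower numbers for a less stable compound

compound 1 `NC1CCC(CN2CCN(c3cc(=O)c4cc(C(F)(F)F)cc([N+](=O)[O-])c4s3)CC2)CC1` gives 107%
compound 2 `Nc1cc(C(F)(F)F)cc2c(=O)cc(N3CCN(CC4CCC(O)CC4)CC3)sc12` gives 60%
compound 3 `O=C(OC1CCC(CN2CCN(c3cc(=O)c4cc(C(F)(F)F)cc([N+](=O)[O-])c4s3)CC2)CC1)C1CCCCC1` gives 1.2%

Compound 3 at 1.2% is the lowest of the three, and compound 2 and compound 1 both lie beyond the scatter above it. The compound still to be measured is compound 4 `O=c1cc(N2CCN(CC3CCC(O)CC3)CC2)sc2c([N+](=O)[O-])cc(C(F)(F)F)cc12` and the change from compound 3 is hydrogen in place of cyclohexylcarbonyl on an oxygen on a saturated carbon with hydrogen in place of cyclohexylcarbonyl on an oxygen on a saturated carbon, which reads as (cyclohexylcarbonyl)oxy to hydroxy. Within the data shown here, the one measured step that bears on this is a number 105.8 percentage points lower from compound 1 to compound 3 (beyond the scatter) with (cyclohexylcarbonyl)oxy in place of amino on a saturated ring carbon, a large step beyond the scatter. Among the measured compounds shown here, it bears only in part, as compound 4 carries hydroxy and not amino, and no measured pair sets hydroxy directly against (cyclohexylcarbonyl)oxy. Compound 2 holds a hydroxy group on a saturated ring carbon and gives 60% in this assay on a different core substitution. A large rise, beyond the scatter, is therefore expected. The expected step is a number 63.8 percentage points higher from compound 3 to compound 4 (beyond the scatter) in this estimate. The estimate for compound 4 is 65% with an expected range from 35% to 95% around it.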

Compound 4, percent of the compound remaining: 51.2%
Compound 4: middle estimate off by 13.8 percentage points, on the high side; the range from low to high includes it.
By their numbers in this assay, from the lowest: compound 3; then compounds 4 and 2 (each within the scatter of the next); then compound 1.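

In this assay the direct pairing of (cyclohexylcarbonyl)oxy with hydroxy on the same core gives a number 50 percentage points higher from compound 3 to compound 4 (beyond the scatter) and so ties the very low number to the (cyclohexylcarbonyl)oxy group rather than to the shared core. Hydroxy does not match amino on the saturated ring carbon either, as the pairing of those two groups gives a number 55.8 percentage points lower from compound 1 to compound 4 (beyond the scatter) and places the three groups in the order amino, hydroxy, (cyclohexylcarbonyl)oxy, from the highest number to the lowest. The group on the aromatic carbon makes no difference that can be told from scatter with hydroxy on the saturated ring carbon, since nitro in place of amino there gives a number 8.8 percentage points lower from compound 2 to compound 4 (within the scatter) and leaves the two hydroxy compounds level.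

The compounds shown leave open whether acetyl on the same oxygen, or a methoxy group or a carboxylic acid on the saturated ring carbon, would fall nearer to hydroxy or to (cyclohexylcarbonyl)oxy. They also leave open whether amino and nitro on the aromatic carbon stay level when the saturated ring carbon carries amino or (cyclohexylcarbonyl)oxy instead of hydroxy. No separate evidence accompanies these numbers to explain any of the differences.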